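This account rests on a few compounds, and the source may have more. Where it says the series, first, only, none or still open, it means among the compounds named here.

Working notes on the series: in a functional assay on DU-145 cells (Homo sapiens) for cytotoxicity, read by trypan blue exclusion, with a stated time of 96 h (a lower number here means a stronger inhibitor, a higher number a weaker inhibitor), compound 1 `COc1cc(OC)c(/C=C/S(=O)(=O)Nc2ccc(OC)c(OP(=O)(O)O)c2)c(OC)c1` gives 40 nM, compound 2 `COC(=O)C(C)(C)Nc1cc(NS(=O)(=O)/C=C/c2c(OC)cc(OC)cc2OC)ccc1OC` gives 200 nM and compound 3 `COC(=O)C(Nc1cc(NS(=O)(=O)/C=C/c2c(OC)cc(OC)cc2OC)ccc1OC)c1ccc(Cl)cc1` gives 5000 nM, the highest number of the three. Compound 4 `COc1cc(OC)c(/C=C/S(=O)(=O)Nc2ccc(OC)c(NC(C(=O)O)c3ccc(F)cc3)c2)c(OC)c1` is still unmeasured. Its difference from compound 3 is carboxy(4-fluorophenyl)methyl in place of (4-chlorophenyl)(methoxycarbonyl)methyl on a nitrogen on an aromatic ring: methoxycarbonyl gives way to carboxy, and 4-chlorophenyl to 4-fluorophenyl, on the same nitrogen on an aromatic ring.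

The closest evidence is the large step of a 25-fold higher number from compound 2 to compound 3 (1.40 log units; beyond the scatter), which shows that the group on this nitrogen can shift this assay strongly. The modest step of a 5.0-fold higher number from compound 1 to compound 2 (0.70 log units; beyond the scatter) involves the same place on the shared core, but with different groups. Among the measured compounds shown here, no measured pair isolates either exchange in compound 4, so the expectation is loose.

With compound 3 at the top of the measured numbers, a modest move downward is expected, an estimated 3.3-fold lower number from compound 3 to compound 4 (0.52 log units; beyond the scatter). For compound 4 the estimated value is 1500 nM, with an expected range of 200 nM to 10000 nM.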

Compound 4, half-maximal inhibitory concentration: 75 nM
The estimate for compound 4 lay 20-fold (1.30 log units) above the measured number; measured number outside the range, below it.
By their numbers in this assay, from the lowest: compounds 1 and 4 (each within the scatter of the next); then compound 2; then compound 3.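

Compound 4 shows that the group on this nitrogen can move the number down as well as up: there is a 67-fold lower number from compound 3 to compound 4 (1.82 log units; beyond the scatter) and also a 2.7-fold lower number from compound 2 to compound 4 (0.43 log units; beyond the scatter) in this assay. An aromatic ring in the group therefore does not by itself bring a high number, since compound 3 and compound 4 both carry one. With a 1.9-fold higher number from compound 1 to compound 4 (0.27 log units; within the scatter) the two compounds cannot be told apart, and nothing available bears on the cause of these steps.

The exchange of methoxycarbonyl for carboxy and that of 4-chlorophenyl for 4-fluorophenyl travel together here, so the compounds shown do not assign the large step to either. Open too, going by these compounds, is how a primary amide or an unsubstituted phenyl in this group would read.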